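Aryl replacement on the side chain: compound 3 to compound 4

The source may report more compounds than this note shows. Statements on the series, on what has been measured and on what is new or still open speak of the compounds shown alone.

compound 1 `O=C(O)CCCSCCN1C(=O)CC[C@@H]1/C=C/[C@@H](O)Cc1cccc(-c2nc3ccccc3s2)c1` — in an assay on CHO cells for displacement of a labelled ligand from prostaglandin E2 receptor EP1 subtype (Mus musculus), read by scintillation counting, with a stated time of 20 min (a lower number here means a stronger inhibitor, a higher number a weaker inhibitor), compound 1 gives > 10000 nM, a limit.
compound 2 `O=C(O)CCCSCCN1C(=O)CC[C@@H]1/C=C/[C@@H](O)Cc1cccc(-c2cc3ccccc3o2)c1` — in this assay compound 2 gives > 10000 nM, a limit.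
compound 3 `O=C(O)c1csc(SCCN2C(=O)CC[C@@H]2/C=C/[C@@H](O)Cc2cccc(-c3ccccc3)c2)n1` — in this assay compound 3 gives 4200 nM.

Within the data shown here, compound 3 holds the only number in the set; the other two values sit at the limit (the limit of > 10000 nM in this assay, at which 2 of the 3 values shown sit). The step that the two limits leave unreadable from compound 1 to compound 2 is therefore unreadable in size. Compound 4 `Cc1ccc2oc(-c3cccc(C[C@H](O)/C=C/[C@H]4CCC(=O)N4CCSc4nc(C(=O)O)cs4)c3)nc2c1` differs from compound 3 by 5-methyl-1,3-benzoxazol-2-yl in place of phenyl on an aromatic carbon. Among the measured compounds shown here, no measured step follows this change. Compounds 1 and 2, which carry 1,3-benzothiazol-2-yl and 1-benzofuran-2-yl on an aromatic carbon, both sit at the limit, but they also differ from compound 3 in the acid tail, so they give no readable size. Compound 4 is expected to be weaker, by an estimated 1.9-fold higher number from compound 3 to compound 4 (0.28 log units; within the scatter), with a fair chance of a limit. The estimate for compound 4 is 8000 nM, range 2500 nM to 30000 nM.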

Compound 4, inhibition constant: 1300 nM
Estimate against measurement, compound 4: 6.2-fold (0.79 log units) above; the whole stated range lies above it.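

In this assay, 5-methyl-1,3-benzoxazol-2-yl in place of phenyl gives a 3.2-fold lower number from compound 3 to compound 4 (0.51 log units; beyond the scatter). Among these compounds, this is the first readable step, and it shows that this aromatic carbon, meta to a large group, accepts two fused aromatic rings with the acid tail of compound 3 kept. Nothing measured here accounts for the gain. The step between compound 1 and compound 2 cannot be read: the limit of > 10000 nM in this assay, at which 2 of the 4 values shown sit.

On these data alone, the share of the methyl in this step stays open, as does the result of an amine in its place. As far as these compounds go, how 1,3-benzothiazol-2-yl and 1-benzofuran-2-yl behave on the acid tail of compound 3 also stays open.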